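Ester Chain Ring Swap and Metabolic Stability

This account rests on a few compounds, and the source may have more. Where it says the series, first, only, none or still open, it means among the compounds named here.

Three compounds built on one shared core were tested in an ADME assay on microsomes from liver (Mus musculus) for metabolic stability, with a stated time of 30 min; a lower number here means that less of the compound is left, a higher number that more of the compound is left. Compound 1 `CCCCc1nc(C(C)C)c(CC(=O)OCCC)c(=O)n1Cc1ccc(-c2ccccc2-c2noc(=O)[nH]2)cc1` gives 12.6%. Compound 2 `CCCCOC(=O)Cc1c(C(C)C)nc(CCCC)n(Cc2ccc(-c3ccccc3-c3noc(=O)[nH]3)cc2)c1=O` gives 21.6%, and the step of a number 9 percentage points higher from compound 1 to compound 2 (within the scatter) lies within the scatter. Compound 3 `CCCCOC(=O)Cc1c(C)nc(CCCC)n(Cc2ccc(-c3ccccc3-c3noc(=O)[nH]3)cc2)c1=O` gives 10.2%, with the step of a number 11.4 percentage points lower from compound 2 to compound 3 (beyond the scatter) on an aromatic carbon, beyond the scatter. Compound 3 thus holds the lowest of the three numbers: compound 1 stands within the scatter of it, while compound 2 stands beyond it.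

Compound 4 `CCCCc1nc(C)c(CC(=O)OCC2CCCCC2)c(=O)n1Cc1ccc(-c2ccccc2-c2noc(=O)[nH]2)cc1` has not been measured. It differs from compound 3 by cyclohexyl in place of propyl on a saturated chain carbon bound to an oxygen next to a carbonyl group. Going by the values given here, only one measured step touches a saturated chain carbon of that same chain, and that step, a number 9 percentage points higher from compound 1 to compound 2 (within the scatter), stayed within the scatter. The step of a number 11.4 percentage points lower from compound 2 to compound 3 (beyond the scatter) concerns an aromatic carbon and gives no guide here. Among the compounds with values here, the change to compound 4 is larger, a six-membered ring entering where propyl sat, so a shift beyond the scatter cannot be ruled out, but the one comparable step suggests a small one. Compound 4 is therefore expected to give 14%, between 6% and 28%. The expected step is a number 3.8 percentage points higher from compound 3 to compound 4 (within the scatter).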

Compound 4, percent of the compound remaining: 8.9%
Compound 4: the middle estimate sits 5.1 percentage points above what was measured, and the stated range covers the measured number.
By their numbers in this assay, from the lowest: compounds 4, 3, 1 and 2 (each within the scatter of the next, the first and the last beyond it).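

Putting cyclohexyl in place of propyl on the saturated chain carbon bound to an oxygen next to a carbonyl group gives, in this assay, a number 1.3 percentage points lower from compound 3 to compound 4 (within the scatter). The earlier compounds shown here compared only open chains at this end of the molecule, whereas this step shows that a six-membered non-aromatic ring of carbon only can sit here without moving the number beyond the scatter. Nothing measured here bears on what lies behind this result.

Still open, as far as these compounds go, is whether a ring or chain carrying other atoms, such as an amine or a carboxylic acid, or an aromatic phenyl ring, would behave the same way at this position. Also open, from the compounds shown here alone, is how cyclohexyl at this position would read alongside the isopropyl of compound 2.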